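Swapping 4-(tert-butyl)benzyl for 4-(tert-butyl)phenyl on an oxygen

The source may hold more compounds than are shown below. What is called first, only, known or untested is meant among the compounds shown, and "the series" means these compounds.

Among the compounds with values here, in a functional assay on JeKo-1 cells (Homo sapiens) for antiproliferative activity (on this read-out lower numbers stand for stronger inhibition and higher numbers for weaker inhibition), compound 1 (`CC(C)(C)c1ccc(COc2ccc(-c3cn([C@H]4CCN(C[C@@H]5CO5)C4)c4ncnc(N)c34)cc2)cc1`) gives 5970 nM as the only number available, so there is no other measured value to rank it against. Compound 2 (`Nc1ncnc2c1c(-c1cnc3[nH]ccc3c1)cn2C[C@H]1CCCN1C[C@@H]1CO1`) has the entry "not determined" (no result reported) and offers no comparison. Compound 3 (`CC(C)(C)c1ccc(Oc2ccc(-c3cn([C@H]4CCN(C[C@@H]5CO5)C4)c4ncnc(N)c34)cc2)cc1`) carries 4-(tert-butyl)phenyl in place of 4-(tert-butyl)benzyl on an oxygen on an aromatic ring. Within the data shown here, no measured step exists as a guide, so no change beyond the usual scatter is expected in this assay and the estimated step is a 1.3-fold lower number from compound 1 to compound 3 (0.12 log units; within the scatter) in size. Compound 3 is expected at 4500 nM with an estimated range from 1300 nM to 15000 nM as the likely span.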

Compound 3, half-maximal inhibitory concentration: 14800 nM
For compound 3 the middle estimate is 3.3-fold (0.52 log units) below the measured one; measured number inside the range.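

Putting 4-(tert-butyl)phenyl in place of 4-(tert-butyl)benzyl on the oxygen gives a 2.5-fold higher number from compound 1 to compound 3 (0.39 log units; beyond the scatter) in this assay, which means weaker inhibition. This first measured step shows that the read-out responds to a small change at this position. No measurement shown accounts for the difference. Going by these compounds, what remains open is how a longer chain on this oxygen, or an amine in place of the tert-butyl group, would read in this assay. A single step cannot establish a trend.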